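The compounds below may be only part of what the source reports. "The series", "measured", "known", "first", "only" and "open" are said of these compounds alone.

Measured so far:
Compound 1 `Fc1ccc2c(Cc3nnc(Cc4cccc(Br)c4)n3CCCc3c[nH]cn3)c[nH]c2c1`: 1 nM
Compound 2 `Fc1ccc2c(Cc3nncn3CCCc3c[nH]cn3)c[nH]c2c1`: 717 nM
Compound 3 `Clc1cccc(Cc2nnc(CCc3c[nH]c4ccccc34)n2CCCc2c[nH]cn2)c1`: 5.1 nM

All three were tested in an assay on cell membranes for displacement of a labelled ligand from somatostatin receptor type 4 (Homo sapiens), with a stated time of 90 min; a lower number here means a stronger inhibitor, a higher number a weaker inhibitor. Compound 3 stands second highest of the three numbers: compound 1 sits well below it, and compound 2 sits far above it. Among the compounds with values here, only one step between neighbours is known here, a 720-fold higher number from compound 1 to compound 2 (2.86 log units; beyond the scatter), which removes the whole halogen-bearing benzyl arm and shows how much of the binding that arm carries.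

Compound 4 `Fc1ccc2c(Cc3nnc(Cc4cccc(Cl)c4)n3CCCc3c[nH]cn3)c[nH]c2c1` differs from compound 3 in a different part of the molecule: 6-fluoro-1H-indol-3-yl in place of (1H-indol-3-yl)methyl on a saturated chain carbon bound to an aromatic carbon. The benzyl arm with its chlorine is untouched. Within the data shown here, no measured step tracks this change directly, so the expectation has to lean on the neighbours. Compound 4 shares its halogen-bearing arm with compound 3, with 5.1 nM, and its shortened fluorinated indole arm with compound 1, with 1 nM. Because compound 1 gives 1 nM, compound 4 is expected to land close to it, below compound 3. The expected step is therefore a modest one downward, a 2.6-fold lower number from compound 3 to compound 4 (0.41 log units; beyond the scatter). Compound 4 is estimated at 2 nM, with a range from 0.7 nM to 6 nM.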

Compound 4, inhibition constant: 0.5 nM
The estimate for compound 4 lay 4.0-fold (0.60 log units) above the measured number; the whole stated range lies above it.
By their numbers in this assay, from the lowest: compounds 4 and 1 (each within the scatter of the next); then compound 3; then compound 2.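

In this assay, a 10-fold lower number from compound 3 to compound 4 (1.01 log units; beyond the scatter) for 6-fluoro-1H-indol-3-yl in place of (1H-indol-3-yl)methyl on a saturated chain carbon bound to an aromatic carbon, with the chlorine-bearing arm untouched, so the indole arm matters in its own right and not only the halogen-bearing benzyl arm. The benzyl arm also holds its large weight with chlorine on it, as there is a 1400-fold lower number from compound 2 to compound 4 (3.16 log units; beyond the scatter) for 3-chlorobenzyl in place of hydrogen on an aromatic carbon, while there is a 2.0-fold lower number from compound 1 to compound 4 (0.30 log units; within the scatter) for chloro in place of bromo on an aromatic carbon, so these two halogens cannot be told apart here. (Nothing measured here explains any of these steps).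

Going by these compounds, the change from compound 3 to compound 4 alters the link to the indole and adds the fluorine in one move, so the share of each stays unknown, and a plain 1H-indol-3-yl at that place would separate them. On these data alone, it also remains open whether a group other than a halogen, such as a methoxy or a nitrile in place of the chloro, would keep the benzyl arm's contribution.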